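A few compounds are considered here, and "the series" means these few. Any claim that something is new, unique, unknown or untested is made for them only; others in the source may bear on it.

Two members of the series have numbers in a functional assay on HCT-116 cells (Homo sapiens) for inhibition, read by colorimetric assay, with a stated time of 3 days; a higher number here means a weaker inhibitor, a lower number a stronger inhibitor. Compound 1 `O=C(CCCCCCNC(=O)C(O)(O)C(F)(F)F)Nc1nc2ccc(Br)cc2o1` gives 12100 nM in this assay. Compound 2 `O=C(CCCCCCNC(=O)C(O)(O)C(F)(F)F)Nc1cccc(Br)c1` gives 3060 nM in this assay, the lower of the two numbers, and the gap to compound 1 lies beyond the scatter. Compound 3 `O=C(CCCCCCNC(=O)C(O)(O)C(F)(F)F)Nc1ccc(Cl)cc1` has not yet been measured. It differs from compound 2 by 4-chlorophenyl in place of 3-bromophenyl on an amide-type nitrogen. No measured pair in the set carries this change, so nothing shown gives its size. The expected step is a 1.3-fold higher number from compound 2 to compound 3 (0.12 log units; within the scatter), small, if anything a slight weakening, and within the scatter. Compound 3 is estimated at 4000 nM, with a range from 1500 nM to 12000 nM.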

Compound 3, half-maximal inhibitory concentration: 4230 nM
Beside the measured number, compound 3's estimate is 1.1-fold (0.02 log units) below it; measured number inside the range.
By their numbers in this assay, from the lowest: compounds 2 and 3 (each within the scatter of the next); then compound 1.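

On the amide-type nitrogen, 4-chlorophenyl in place of 3-bromophenyl gives a 1.4-fold higher number from compound 2 to compound 3 (0.14 log units; within the scatter) in this assay. This single step changes both the halogen and its place on the ring, and together these two differences give no separation beyond the scatter. Nothing shown offers an explanation for this result.

On these data alone, the separate contributions of halogen and ring place remain open, and 3-chlorophenyl or 4-bromophenyl would separate them. Also open, as far as these compounds go, is whether an aminophenyl or carboxyphenyl group here would move the number beyond the scatter.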